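The compounds below may be only part of what the source reports. "The series", "measured", "known", "first", "only" and "open" are said of these compounds alone.

Compound 1 `CCCc1ccc(C(=O)Nc2cccc(NC(=O)COc3ccc4c(=O)ccoc4c3)c2)cc1` sets the reference for the shared core, and in an assay on isolated protein for inhibition of Rho-associated protein kinase 1 (Homo sapiens), read by scintillation counting, radiometric assay and 33P incorporation, with a stated time of 40 min, in the presence of a further agent that is not named here (a higher number here means a weaker inhibitor, a lower number a stronger inhibitor), compound 1 gives 143 nM. Compound 2 `CC(C)(C)c1cc(C(=O)Nc2cccc(NC(=O)COc3ccc4c(=O)ccoc4c3)c2)no1` gives 101 nM in this assay. The step of a 1.4-fold lower number from compound 1 to compound 2 (0.15 log units; within the scatter) shows that swapping a six-membered carbon ring for a five-membered ring with two hetero atoms on the carbonyl carbon leaves the read-out where it was. Compound 3 `Cn1ccc(S(=O)(=O)Nc2cccc(NC(=O)COc3ccc4c(=O)ccoc4c3)c2)n1` carries a sulfonamide in place of the amide. In this assay compound 3 reaches only a limit of the assay, > 10000 nM, so no number is known for it. This is the value sitting at the limit of > 10000 nM in this assay, at which 1 of the 3 values shown sits. The steps of an at least 69-fold higher number from compound 1 to compound 3 (1.84 log units; beyond the scatter) and an at least 99-fold higher number from compound 2 to compound 3 (1.99 log units; beyond the scatter) are both large and point the same way.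

Compound 4 `CN(C)c1ccc(S(=O)(=O)Nc2cccc(NC(=O)COc3ccc4c(=O)ccoc4c3)c2)cc1` keeps the sulfonamide of compound 3 and differs in one place: 4-(dimethylamino)phenyl in place of 1-methyl-1H-pyrazol-3-yl on a sulfonyl sulfur. No measured step exchanges groups on the sulfonyl sulfur, so nothing shown bears directly on this change; the only ring-for-ring exchange of this kind is a 1.4-fold lower number from compound 1 to compound 2 (0.15 log units; within the scatter), and it stayed within the scatter. Compound 3 stands at a limit. Compound 4 is therefore expected to remain near that limit in this assay, with an estimated 12000 nM, between 3000 nM and 50000 nM. The expected step that the limit leaves unreadable from compound 3 to compound 4 is estimated to be none beyond the scatter.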

Compound 4, half-maximal inhibitory concentration: 803 nM
Estimate against measurement, compound 4: 15-fold (1.17 log units) above; the measured number lies below the stated range.
By their numbers in this assay, from the lowest: compounds 2 and 1 (each within the scatter of the next); then compound 4. At a limit, above all of these: compound 3.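

In this assay, among the compounds shown here, the group on the sulfonyl sulfur proves to matter: the change to 4-(dimethylamino)phenyl gives an at least 12-fold lower number from compound 3 to compound 4 (1.09 log units; beyond the scatter), whereas the only earlier ring exchange, made on a carbonyl carbon, gave a 1.4-fold lower number from compound 1 to compound 2 (0.15 log units; within the scatter). The sulfonamide therefore does not by itself rule out a measurable read-out, as compound 4 keeps that linkage and still gives a measured value of 803 nM. The true size of the step remains unknown because compound 3 gives only a limit, not a number: the limit of > 10000 nM in this assay, at which 1 of the 4 values shown sits.

The compounds shown do not separate the contribution of the six-membered carbon ring from that of the dimethylamino group, so it remains open whether a plain phenyl on the sulfonyl sulfur would behave like 4-(dimethylamino)phenyl or like 1-methyl-1H-pyrazol-3-yl. On these data alone, it is also open how a methoxy group or a carboxylic acid in place of the dimethylamino group would read in this assay, and whether a 5-(tert-butyl)-1,2-oxazol-3-yl group would carry over from the carbonyl carbon to the sulfonyl sulfur.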